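Working notes: from compound 3 to compound 4

The source may report more compounds than this note shows. Statements on the series, on what has been measured and on what is new or still open speak of the compounds shown alone.

Among the measured compounds shown here, in a functional assay on A549 cells (Homo sapiens) for antiproliferative activity, read by sulforhodamine B assay, with a stated time of 72 h (on this read-out lower numbers stand for stronger inhibition and higher numbers for weaker inhibition), compound 3 (`CC(=O)Oc1cc2c(CCC=C(C)C)c(C)ccc2cc1C(C)C`) gives 25500 nM, the only actual number in this set. Compound 1 (`Cc1ccc(/C=C(\C(=O)O)C(C)C)c2c1CC[C@@H](C(C)(C)O)OC2=O`) reads > 100000 nM, which is a limit of the assay. Compound 2 (`Cc1ccc(/C=C(\C(=O)O)C(C)C)c2c1CC[C@H](C(C)(C)O)OC2=O`) reads > 100000 nM, also a limit.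

Compound 4 (`CC(=O)Oc1cc2c(CC[C@H](O)C(C)(C)O)c(C)ccc2cc1C(C)C`) differs from compound 3 by 1,2-dihydroxy-2-methylpropyl in place of 2-methylprop-1-en-1-yl on a saturated chain carbon, two bonds along the chain from an aromatic carbon.

For the measured compounds named here, the one measured step is a step that the two limits leave unreadable from compound 1 to compound 2. It concerns (the fact that compounds 1 and 2 differ only in the configuration as drawn), not this change, and gives no size to carry over. The set also offers (the limit of > 100000 nM in this assay, at which 2 of the 3 values shown sit), which points to the weak side of this assay without fixing a size. A moderate move towards weaker inhibition is therefore expected, with wide uncertainty and a real chance of a limit reading. The estimated change is a 1.8-fold higher number from compound 3 to compound 4 (0.25 log units; within the scatter). For compound 4 the expected value is 45000 nM, with an estimated range of 15000 nM to 100000 nM.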

Compound 4, half-maximal inhibitory concentration: 50500 nM
Compound 4: middle estimate off by 1.1-fold (0.05 log units), on the low side, and the stated range covers the measured number.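

In this assay, among the compounds shown here, putting 1,2-dihydroxy-2-methylpropyl in place of 2-methylprop-1-en-1-yl on a saturated chain carbon, two bonds along the chain from an aromatic carbon, gives the first step in this set with a readable size: a 2.0-fold higher number from compound 3 to compound 4 (0.30 log units; within the scatter). At this place on the shared core, the change adds two hydrogen-bond donors, two hydrogen-bond acceptors and a defined stereocentre, yet the two readings stay within the scatter of each other. Nothing shown gives a cause for this step.

As far as these compounds go, it remains open whether the other configuration at the new stereocentre would read the same as compound 4. From the compounds shown here alone, it is also open whether an amine or a carboxylic acid at this place would separate from compound 3 and compound 4.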